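Adding a Methoxy Group to an Anilino Ring

This account rests on a few compounds, and the source may have more. Where it says the series, first, only, none or still open, it means among the compounds named here.

Compound 1 `CC(C)c1ccc(-c2nc(SCc3cn(CC(=O)NC(=O)Nc4ccccn4)nn3)nc(Nc3cccc(Cl)c3)c2C#N)cc1` gives 18000 nM in a functional assay on MCF7 cells (Homo sapiens) for inhibition, read by MTT assay, with a stated time of 72 h; a higher number here means a weaker inhibitor, a lower number a stronger inhibitor. Compound 2 `CC(C)c1ccc(-c2nc(SCc3cn(CC(=O)NC(=O)Nc4ccccn4)nn3)nc(Nc3ccccc3)c2C#N)cc1` differs only by hydrogen in place of chloro on an aromatic carbon, and that change gives an at least 3.5-fold higher number from compound 1 to compound 2 (0.55 log units; beyond the scatter). Compound 2 reaches only a limit in this assay, > 64000 nM; this is the limit of > 64000 nM in this assay, at which 1 of the 2 values shown sits. Compound 3 `COc1ccccc1Nc1nc(SCc2cn(CC(=O)NC(=O)Nc3ccccn3)nn2)nc(-c2ccc(C(C)C)cc2)c1C#N` carries methoxy in place of hydrogen on an aromatic carbon, ortho to a large group. For the measured compounds named here, no measured step covers a methoxy group, so the only guide is that the bare ring is weaker than the chloro ring. The step from compound 2 to compound 3 is expected to be an at least 1.6-fold lower number from compound 2 to compound 3 (0.20 log units; that floor lies within the scatter). For compound 3 the estimate is 40000 nM, between 12000 nM and 130000 nM.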

Compound 3, half-maximal inhibitory concentration: 19300 nM
For compound 3 the middle estimate is 2.1-fold (0.32 log units) above the measured one; low and high end bracket the measured number.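

Methoxy in place of hydrogen on this aromatic carbon gives an at least 3.3-fold lower number from compound 2 to compound 3 (0.52 log units; beyond the scatter), so chloro is not the only group on this ring that yields a measured number in this assay. Swapping the ring substituents gives a 1.1-fold higher number from compound 1 to compound 3 (0.03 log units; within the scatter), which leaves the two substituted rings indistinguishable here. The full size of the step from the bare ring stays unknown because compound 2 stands at a limit: the limit of > 64000 nM in this assay, at which 1 of the 3 values shown sits.

Still open, on these data alone, is whether the methoxy result depends on where the group sits on the ring, and whether an amine or a hydroxyl group there would give a similar number.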